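Branching the Amide Chain: Propyl to Isopropyl

The compounds below may be only part of what the source reports. "The series", "measured", "known", "first", "only" and "open" are said of these compounds alone.

Compound 2 `CCCNC(=O)CC1CCc2cc(OC)c(OC)cc21` carries a propyl group on its amide nitrogen. In a functional assay on the whole organism (strain Wistar) for inhibition, with Rattus norvegicus as the target, read by paw edema, with stated times of 60 min and 1 h, at a dose of 100 mg/kg by the oral route (on this read-out lower numbers stand for less inhibition and higher numbers for more inhibition at the one dose given (going by the name of the read-out)), compound 2 gives 18.8%, and compound 1 `CNC(=O)CC1CCc2cc(OC)c(OC)cc21` gives 15.6%, the two numbers within the usual scatter of each other; the step of a number 3.2 percentage points higher from compound 1 to compound 2 (within the scatter). Compound 3 `COc1cc2c(cc1OC)C(CC(=O)NC(C)C)CC2` differs from compound 2 by isopropyl in place of propyl on an amide-type nitrogen. Going by the values given here, no measured step swaps one chain for another of the same size on that nitrogen, and the only chain change seen stayed within the scatter. The step from compound 2 to compound 3 is therefore expected to be small: a number 0.8 percentage points lower from compound 2 to compound 3 (within the scatter). Compound 3 is estimated at 18%, within 8% to 28%.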

Compound 3, a percentage reported as inhibition, in the whole organism at one dose (the size of the read-out at that dose, not a potency): 31.3%
Estimate against measurement, compound 3: 13.3 percentage points below, and the stated range ends below it.
By their numbers in this assay, from the lowest: compounds 1 and 2 (each within the scatter of the next); then compound 3.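

Moving from the straight propyl to the branched isopropyl keeps the same carbons on the amide-type nitrogen, yet the number changes beyond the scatter (a number 12.5 percentage points higher from compound 2 to compound 3 (beyond the scatter)). So how the chain is branched counts at this position, and isopropyl also stands clear of the smaller methyl (a number 15.7 percentage points higher from compound 1 to compound 3 (beyond the scatter)). Nothing available here explains this gain. On these data alone, whether a more heavily branched tert-butyl group or a cyclopentyl ring on this nitrogen would raise the number further remains open. As far as these compounds go, whether the gain holds at other doses also remains open.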